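Moving the Acid and Swapping Methyl for Fluorine

This account rests on a few compounds, and the source may have more. Where it says the series, first, only, none or still open, it means among the compounds named here.

compound 1 `Cc1ncc(OCCCCOc2ccc(C(=O)CC(C)(C)C)c(O)c2C)cc1C(=O)O`: 79 nM
compound 2 `Cc1c(OCCCCOc2ccc(Cl)c(C(=O)O)c2)ccc(C(=O)CC(C)(C)C)c1O`: 130 nM
compound 3 `Cc1ccc(OCCCCOc2ccc(C(=O)CC(C)(C)C)c(O)c2C)cc1C(=O)O`: 309 nM

In an assay for positive allosteric modulation of metabotropic glutamate receptor 3 (Rattus norvegicus) (on this read-out higher numbers stand for an effect only at larger amounts of compound and lower numbers for an effect already at smaller amounts), compound 3 gives 309 nM, the highest of the three numbers. The two steps leading to it are both beyond the scatter: a 2.4-fold higher number from compound 2 to compound 3 (0.38 log units; beyond the scatter) and a 3.9-fold higher number from compound 1 to compound 3 (0.59 log units; beyond the scatter). The step of a 1.6-fold higher number from compound 1 to compound 2 (0.22 log units; within the scatter), by contrast, stays within the scatter, so compounds 1 and 2 cannot be ranked against each other.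

Compound 4 `Cc1c(OCCCCOc2ccc(C(=O)O)c(F)c2)ccc(C(=O)CC(C)(C)C)c1O` has not been measured. Its change from compound 3 is 4-carboxy-3-fluorophenyl in place of 3-carboxy-4-methylphenyl on an oxygen on a saturated carbon. This change does two things at once: it moves the carboxylic acid to a different position on the ring, and it replaces methyl with fluorine. For the measured compounds named here, only one measured step touches this part of the molecule, the exchange of chloro for methyl in a 2.4-fold higher number from compound 2 to compound 3 (0.38 log units; beyond the scatter), and it is of modest size. Going by the values given here, no measured step moves the carboxylic acid, so there is no direct guide for the larger part of the change.

The expected step is therefore a 1.0-fold lower number from compound 3 to compound 4 (0.01 log units; within the scatter), with a wide range around it. Compound 4 is estimated at 300 nM, between 90 nM and 1200 nM.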

Compound 4, half-maximal effective concentration: 1110 nM
For compound 4 the middle estimate is 3.7-fold (0.57 log units) below the measured one; the range from low to high includes it.
By their numbers in this assay, from the lowest: compounds 1 and 2 (each within the scatter of the next); then compound 3; then compound 4.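

In this assay the move to 4-carboxy-3-fluorophenyl gives a 3.6-fold higher number from compound 3 to compound 4 (0.56 log units; beyond the scatter) and is the first change shown that shifts the carboxylic acid around the ring, so the number at this spot on the saturated chain's oxygen depends on more than the small group that the earlier compounds varied. Measured against the other two groups, the same change gives an 8.5-fold higher number from compound 2 to compound 4 (0.93 log units; beyond the scatter) and a 14-fold higher number from compound 1 to compound 4 (1.15 log units; beyond the scatter), the second being the largest step in the set and the only one of large size, which leaves compound 4 with the highest number of the four. No measurement on hand speaks to the reason for these rises.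

The compounds shown leave open how much of the rise belongs to the moved carboxylic acid and how much to fluorine in place of methyl, as compound 4 changes both at once. A 3-carboxy-4-fluorophenyl group would keep the acid where compounds 2 and 3 carry it and change only the small group, and an amide in place of the carboxylic acid would test whether the acid itself is needed at all.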